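Changing the sulfonyl group beyond compound 2

The source may report more compounds than this note shows. Statements on the series, on what has been measured and on what is new or still open speak of the compounds shown alone.

Measured in an ADME assay on microsomes from liver (Mus musculus, strain CD-1) for metabolic stability, read by LC-MS, tested at 2 uM; on this read-out higher numbers stand for a longer-lived compound and lower numbers for a shorter-lived compound
- compound 1 `CN(C)S(=O)(=O)c1ccccc1Nc1cc(-c2ccc3ccn(C)c3c2)c2nccnc2c1` gives 0.233 h
- compound 2 `Cn1ccc2ccc(-c3cc(Nc4ccccc4S(=O)(=O)N4CCOCC4)cc4nccnc34)cc21` gives 0.367 h

Among the compounds with values here, only one measured comparison places compound 2 , and it shows a 1.6-fold higher number from compound 1 to compound 2 (0.20 log units; within the scatter), so the two values cannot be ranked. Compound 3 `CN(Cc1cncnc1)S(=O)(=O)c1ccccc1Nc1cc(-c2ccc3ccn(C)c3c2)c2nccnc2c1` has not yet been measured. It carries methyl((pyrimidin-5-yl)methyl)amino in place of morpholin-4-yl on a sulfonyl sulfur. Within the data shown here, the single measured step bears on this change. It swaps the group on that same sulfonyl sulfur, morpholin-4-yl in place of dimethylamino. Among the measured compounds shown here, no measured compound carries the incoming group, however, so the guidance is thin. No step beyond the scatter is therefore expected in this assay. The estimate amounts to a 1.4-fold lower number from compound 2 to compound 3 (0.13 log units; within the scatter), an expected change that stays modest. Compound 3 is estimated at 0.27 h, with an expected range from 0.12 h to 0.55 h.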

Compound 3, half-life: 0.2 h
Compound 3: middle estimate off by 1.4-fold (0.13 log units), on the high side; the measured number falls inside the stated range.
By their numbers in this assay, from the lowest: compounds 3, 1 and 2 (each within the scatter of the next).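

In this assay, methyl((pyrimidin-5-yl)methyl)amino in place of morpholin-4-yl on the sulfonyl sulfur gives a 1.8-fold lower number from compound 2 to compound 3 (0.26 log units; within the scatter). Pyrimidin-5-yl in place of hydrogen on the saturated chain carbon bound to the sulfonamide nitrogen gives a 1.2-fold lower number from compound 1 to compound 3 (0.07 log units; within the scatter). The earlier pair showed only dimethylamino and morpholin-4-yl at this place, whereas these steps show that a group with an aromatic ring can stand there with no step beyond the scatter from either compound. No measurement at hand accounts for these small differences.

The compounds shown leave open whether another amine on the sulfonyl sulfur, such as piperidine or azetidine, would move the half-life beyond the scatter. They also leave open whether a phenyl ring in place of pyrimidin-5-yl would read any differently from compound 3.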